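This account rests on a few compounds, and the source may have more. Where it says the series, first, only, none or still open, it means among the compounds named here.

Compound 1 `O=C(NO)c1ccc(NCc2nc(-c3ccc(F)cc3)nn2-c2ccccc2)cc1` and compound 2 `Cc1cccc(-n2nc(-c3ccccc3)nc2CNc2ccc(C(=O)NO)cc2)c1` share a core, and in an assay on Sf9 cells for inhibition of protein deacetylase HDAC6 (Homo sapiens), read by fluorescence, with a stated time of 40 min, tested at 100 nM (a lower number here means less inhibition, a higher number more inhibition at the concentration tested (going by the name of the read-out)), compound 1 gives 70.9% while compound 2 gives 66%, two numbers within the usual scatter of each other, so neither is set apart. Compound 3 `O=C(NO)c1ccc(NCc2nc(-c3ccncc3)nn2-c2ccccc2)cc1` is not yet measured; it differs from compound 1 by pyridin-4-yl in place of 4-fluorophenyl on an aromatic carbon. For the measured compounds named here, no measured pair showing this change exists, so the step from compound 1 to compound 3 is expected to be small, likely within the scatter, in either direction: a number 5.9 percentage points lower from compound 1 to compound 3 (within the scatter). For compound 3 the estimated value is 65%, expected between 45% and 82%.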

Compound 3, a percentage reported as inhibition, at one concentration (the size of the read-out at that concentration, not a potency): 30.8%
Estimate against measurement, compound 3: 34.2 percentage points above; measured number outside the range, below it.
By their numbers in this assay, from the lowest: compound 3; then compounds 2 and 1 (each within the scatter of the next).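

For the compounds shown here, at this position of the shared core the aryl group matters: in this assay, pyridin-4-yl in place of 4-fluorophenyl gives a number 40.1 percentage points lower from compound 1 to compound 3 (beyond the scatter), the first step beyond the scatter. The step swaps a ring of carbon only for a ring with one hetero atom and also removes the fluorine, and the pair cannot separate these two differences. Nothing at hand bears on the reason for this step.

Open, going by these compounds, is whether the ring nitrogen or the missing fluorine carries the step. A pyridin-3-yl or 4-methoxyphenyl group at this position would test how specific it is.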